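The source may report more compounds than this note shows. Statements on the series, on what has been measured and on what is new or still open speak of the compounds shown alone.

Compound 1 `COCC(=O)N(Cc1ccc(OC)c(O)c1)c1cc(OC)c(OC)c(OC)c1`: 79 nM
Compound 2 `C/C=C/C(=O)N(Cc1ccc(OC)c(C)c1)c1cc(OC)c(OC)c(OC)c1`: 14500 nM

Within the data shown here, in a functional assay on MGC-803 cells (Homo sapiens) for inhibition, read by MTT assay, with a stated time of 48 h (on this read-out lower numbers stand for stronger inhibition and higher numbers for weaker inhibition), compound 1 gives 79 nM, the lower of the two numbers so far, while compound 2 gives 14500 nM, a gap beyond the usual scatter. Compound 3 `COc1ccc(CN(C(=O)C[Se]C#N)c2cc(OC)c(OC)c(OC)c2)cc1O` has not yet been measured. It differs from compound 1 by a group of 3 heavy atoms (1 carbon, 1 nitrogen, 1 selenium; no ring) in place of a group of 2 heavy atoms (1 carbon, 1 oxygen; no ring), on a saturated chain carbon bound to a carbonyl carbon. Among the measured compounds shown here, no two measured compounds differ in a single place, so nothing shows how such a change moves the number. The step is expected to fall within the scatter, in either direction: a 1.3-fold lower number from compound 1 to compound 3 (0.12 log units; within the scatter). Compound 3 is estimated at 60 nM, in the range 15 nM to 250 nM.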

Compound 3, half-maximal inhibitory concentration: 270 nM
The estimate for compound 3 lay 4.5-fold (0.65 log units) below the measured number, and the stated range ends below it.
By their numbers in this assay, from the lowest: compound 1; then compound 3; then compound 2.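

In this assay, among these compounds, the first comparison that changes one place only gives a 3.4-fold higher number from compound 1 to compound 3 (0.53 log units; beyond the scatter) when methoxy gives way to the group of carbon, nitrogen and selenium on a saturated chain carbon bound to a carbonyl carbon. This position therefore responds to the change, though the step is modest and counts as beyond the scatter. No measurement at hand accounts for the step. The compounds shown leave open whether the same group with sulfur in place of selenium, an amine or a longer chain would give a lower number than methoxy. They also leave open whether this step would hold on a different core.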